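The source may report more compounds than this note shows. Statements on the series, on what has been measured and on what is new or still open speak of the compounds shown alone.

Among the measured compounds shown here, in an assay on HEK293 cells for inhibition of N-acylethanolamine-hydrolyzing acid amidase (Rattus norvegicus), read by LC-MS, with a stated time of 30 min (on this read-out higher numbers stand for weaker inhibition and lower numbers for stronger inhibition), compound 3 `O=C(CCCCCc1ccc(Cl)cc1)N1CCOC1=O` gives 4600 nM, the higher of the two plain numbers measured so far. Compound 1 `O=C(CCCCCc1ccc(O)c(F)c1)N1CCOC1=O` gives 160 nM in this assay, and the gap between these two values lies beyond the usual scatter of repeated measurements. Compound 2 `O=C(O)c1cccc(CCCCCC(=O)N2CCOC2=O)c1` gives only a limit of the assay and not a number, > 20000 nM in this assay.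

Compound 4 `Cc1ccc(CCCCCC(=O)N2CCOC2=O)cc1` differs from compound 3 in a single place: methyl in place of chloro on an aromatic carbon. For the measured compounds named here, no measured pair shows this exchange, so its effect is unknown here. With both groups of the same count and no change in donors, acceptors or charge, the step from compound 3 to compound 4 is expected to be small, a 1.1-fold higher number from compound 3 to compound 4 (0.04 log units; within the scatter), within or near the scatter. Compound 4 is therefore estimated at about 5000 nM in this assay, between 1500 nM and 16000 nM.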

Compound 4, half-maximal inhibitory concentration: 440 nM
Estimate against measurement, compound 4: 11-fold (1.06 log units) above, outside the stated range (below it).
By their numbers in this assay, from the lowest: compound 1; then compound 4; then compound 3. At a limit, above all of these: compound 2.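

At the aromatic carbon para to a large group, methyl in place of chloro gives a 10-fold lower number from compound 3 to compound 4 (1.02 log units; beyond the scatter) in this assay. This position therefore tells apart two groups that match in heavy-atom count, with no hydrogen-bond donors or acceptors and no net charge. Nothing measured here explains why the exchange matters so much. From the compounds shown here alone, it remains open how an ethyl, a methoxy or an amine at this same place would read, and whether methyl would keep its advantage over chloro on a longer chain.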